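The source may hold more compounds than are shown below. What is called first, only, known or untested is meant among the compounds shown, and "the series" means these compounds.

Compound 1 `c1cc(-c2cn[nH]c2)c2c(c1)C(c1ncc[nH]1)CC2` was tested in a functional assay on CHO cells for agonist activity at Alpha-1A adrenergic receptor (Homo sapiens), read by FLIPR and calcium flux (a lower number here means a smaller maximal response, a higher number a larger maximal response), and gave a maximal response of 84%. Of the two numbers recorded so far, compound 1 stands at the top, yet the distance to compound 2 `Cc1ccc2c(c1NS(C)(=O)=O)CCC2c1ncc[nH]1`, which in this assay gave 83%, lies within the usual scatter, so the two compounds cannot be told apart on this read-out. Compound 3 `c1cc(-c2ccn[nH]2)c2c(c1)C(c1ncc[nH]1)CC2` has not yet been measured in this assay. It differs from compound 1 in one place: 1H-pyrazol-5-yl in place of 1H-pyrazol-4-yl on an aromatic carbon. Among the compounds with values here, no step between two measured compounds is available as a guide, so the size of the effect of this change has no precedent here. Since compound 1 gives 84%, compound 3 is expected to land close by, with a step of a number 4 percentage points lower from compound 1 to compound 3 (within the scatter) that stays within the scatter. The estimated maximal response for compound 3 is 80%, within a range of 62% to 95%.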

Compound 3, largest response reached (Emax), in percent of the reference or control that the assay uses: 83%
Estimate against measurement, compound 3: 3 percentage points below, within the range that was stated.
By their numbers in this assay, from the lowest: compounds 2, 3 and 1 (each within the scatter of the next).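

In this assay, within the data shown here, replacing 1H-pyrazol-4-yl with 1H-pyrazol-5-yl on the aromatic carbon gives a number 1 percentage points lower from compound 1 to compound 3 (within the scatter) as the first step that can be read at this position. The two groups have the same atoms, joined differently, and the same counts of hydrogen-bond donor and acceptor, and this read-out cannot tell them apart on the core of compound 1. No measurement shown here accounts for this result.

On these data alone, what stays open is whether the maximal response would hold if a different group took this position, such as a simple amine, a carboxylic acid or a longer alkyl chain. A single pair also leaves open whether the same exchange would behave alike on another core, such as that of compound 2.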